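The source may report more compounds than this note shows. Statements on the series, on what has been measured and on what is new or still open speak of the compounds shown alone.

Measured compounds:

- Compound 1, `O=[N+]([O-])c1ccc(C2=NOC(c3ccc(-c4ccncc4)cc3)C2)o1`: in an ADME assay on HeLa cells (Homo sapiens) for cytotoxicity, read by MTT assay, with a stated time of 96 h (a lower number here means a stronger inhibitor, a higher number a weaker inhibitor), compound 1 gives > 50000 nM, which is a limit of the assay and not a number.
- Compound 2, `O=[N+]([O-])c1ccc(C2=NOC(c3ccc(N4CCN(Cc5ccc(F)nc5)CC4)cc3)C2)o1`: in this assay compound 2 gives > 50000 nM, again a limit of the assay rather than a number.

For the measured compounds named here, compound 2 therefore stands only at a limit, and nothing more precise can be said of where it sits; the one further value shown is a limit as well, so that both values reach (the limit of > 50000 nM in this assay, at which 2 of the 2 values shown sit). Going by the values given here, there is no step between measured compounds that differ in one place, and so no measured step can guide the next comparison.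

Compound 3, `O=[N+]([O-])c1ccc(C2=NOC(c3ccc(N4CCN(Cc5cccnc5)CC4)cc3)C2)o1`, differs from compound 2 in a single place: hydrogen in place of fluoro on an aromatic carbon. With both known values sitting at the same limit, no step beyond the usual scatter is expected in this assay, in either direction. The expected step from compound 2 to compound 3 is a step that the limit leaves unreadable from compound 2 to compound 3. Compound 3 is accordingly estimated at 80000 nM in this assay, with a range from 30000 nM to 300000 nM, and most likely the assay will again report only a limit for compound 3.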

Compound 3, half-maximal inhibitory concentration: > 50000 nM
Compound 3 gave a limit, no number; the forecaster's own chance of this, stated with the estimate: 90%; the middle value is on the limit's open side.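

No step can be read from compound 2 to compound 3 in this assay, since each gives only a limit of the assay and no number: the limit of > 50000 nM in this assay, at which 3 of the 3 values shown sit. The compounds shown leave open how far apart their true values lie, and whether any structure of this series reaches a measurable value in this assay.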